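Swapping a fluorophenyl for a methylpyrazole on a shared core

A few compounds are considered here, and "the series" means these few. Any claim that something is new, unique, unknown or untested is made for them only; others in the source may bear on it.

Among the measured compounds shown here, in a functional assay on SNU-5 cells (Homo sapiens) for inhibition, read by CCK-8 assay, with a stated time of 72 h (on this read-out lower numbers stand for stronger inhibition and higher numbers for weaker inhibition), compound 2 (`CC(c1ccc2ncc(-c3ccc(F)cc3)cc2c1)n1nnc2ncc(-c3ccncc3)nc21`) gives 7 nM, the higher of the two numbers known here. Compound 3 (`CC(c1ccc2ncc(-c3cnn(C)c3)cc2c1)n1nnc2ncc(-c3ccc(C(N)=O)c(F)c3)nc21`) gives 0.7 nM in this assay, a gap beyond the usual scatter, though the two structures differ in more than one place. For compound 1 (`CNC(=O)c1ccc(-c2cnc3nnn(C(C)c4ccc5nc(-c6cnn(C)c6)ccc5c4)c3n2)cc1F`) the entry reads "not determined" (no result reported). Compound 4 (`CC(c1ccc2ncc(-c3cnn(C)c3)cc2c1)n1nnc2ncc(-c3ccncc3)nc21`) is compound 2 with one change: 1-methyl-1H-pyrazol-4-yl in place of 4-fluorophenyl on an aromatic carbon. For the measured compounds named here, no single-change pair speaks to this swap directly, so the expectation leans on compound 3, whose 0.7 nM shows the methylpyrazole-bearing series can run low. The expected step of a 2.3-fold lower number from compound 2 to compound 4 (0.37 log units; beyond the scatter) is a modest lowering, near the edge of scatter. Compound 4 is therefore estimated at 3 nM, within 1 nM to 15 nM.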

Compound 4, half-maximal inhibitory concentration: 1.2 nM
The estimate for compound 4 lay 2.5-fold (0.40 log units) above the measured number; low and high end bracket the measured number.
By their numbers in this assay, from the lowest: compounds 3 and 4 (each within the scatter of the next); then compound 2.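

In this assay, putting 1-methyl-1H-pyrazol-4-yl in place of 4-fluorophenyl gives a 5.8-fold lower number from compound 2 to compound 4 (0.77 log units; beyond the scatter) on an otherwise unchanged structure, so the group on this aromatic carbon clearly matters. The other step, with pyridin-4-yl in place of 4-carbamoyl-3-fluorophenyl, gives a 1.7-fold higher number from compound 3 to compound 4 (0.23 log units; within the scatter) and so shows that, with the methylpyrazole in place, these two groups cannot be told apart in this read-out. Still open, going by these compounds, is how a small amine or a carboxylic acid on the same aromatic carbon would fare. Nothing measured here gives a reason for either step.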